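A few compounds are considered here, and "the series" means these few. Any claim that something is new, unique, unknown or untested is made for them only; others in the source may bear on it.

Measured so far:
- compound 1, `CCCSc1nc(N/N=C/c2ccccc2Cl)c2nnn(Cc3ccccc3)c2n1`: 13800 nM
- compound 2, `CCCSc1nc(N/N=C(\C)c2ccccc2O)c2nnn(Cc3cccc(Cl)c3)c2n1`: 39900 nM

Both compounds were tested in a functional assay on MCF7 cells (Homo sapiens) for antiproliferative activity, read by MTT assay, with a stated time of 72 h; on this read-out higher numbers stand for weaker inhibition and lower numbers for stronger inhibition. Compound 1 gives the lower of the two numbers, and its gap to compound 2 lies beyond the usual scatter, so on these two values compound 1 is the stronger inhibitor. Nothing more can be read from the pair, since the two compounds differ in more than one place.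

Compound 3, `CCCSc1nc(N/N=C(\C)c2ccc(O)cc2)c2nnn(Cc3ccccc3)c2n1`, has not yet been measured in this assay. It differs from compound 1 in one place: a group of 10 heavy atoms (8 carbon, 1 nitrogen, 1 oxygen; one six-membered aromatic ring of carbon only) in place of a group of 9 heavy atoms (7 carbon, 1 nitrogen, 1 chlorine; one six-membered aromatic ring of carbon only), on a nitrogen on an aromatic ring. No single-change step between measured compounds is available to guide this change, so the expectation rests only on the two numbers shown. Among the measured compounds shown here, the one measured compound that carries a hydroxyl group and the extra methyl, compound 2, gives 39900 nM, a weaker inhibition than compound 1, though its other change clouds the comparison. A modest loss in potency, near the edge of the scatter, is therefore expected for compound 3, as the step of a 1.8-fold higher number from compound 1 to compound 3 (0.26 log units; within the scatter). Compound 3 is estimated at 25000 nM, within a range of 8000 nM to 80000 nM.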

Compound 3, half-maximal inhibitory concentration: 21600 nM
Estimate against measurement, compound 3: 1.2-fold (0.06 log units) above, within the range that was stated.
By their numbers in this assay, from the lowest: compounds 1, 3 and 2 (each within the scatter of the next, the first and the last beyond it).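

Among the compounds shown here, on a nitrogen on an aromatic ring, putting a group of 10 heavy atoms that carries a hydroxyl and a methyl in place of a group of 9 heavy atoms that carries a chlorine gives a 1.6-fold higher number from compound 1 to compound 3 (0.19 log units; within the scatter) in this assay and provides the first comparison here of two compounds that differ in one place only. It shows that this position accepts both groups with the two compounds reading alike, so the chlorine is not needed for the level of activity seen with compound 1 in this cell-based test. Nothing available here explains why the two groups read alike.

The chlorine, the hydroxyl and the methyl all differ in this single step, so the compounds shown cannot separate what each contributes, and a compound with only one of them altered would be needed to do so. On these data alone, how an amine or a carboxylic acid on that aromatic ring, or a longer chain in place of the methyl, would read in this assay also remains open.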